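A few compounds are considered here, and "the series" means these few. Any claim that something is new, unique, unknown or untested is made for them only; others in the source may bear on it.

Measured so far in an assay on CHO cells for displacement of a labelled ligand from adenosine receptor A3 (Homo sapiens), with a stated time of 60 min, tested at 10 uM; a higher number here means more inhibition at the concentration tested (going by the name of the read-out), a lower number less inhibition:
compound 1 `O[C@@H]1[C@H](O)CS[C@H]1Cn1cnc2c(NCc3cccc(Br)c3)nc(Cl)nc21` gives 21%
compound 2 `O[C@@H]1[C@H](O)CS[C@H]1Cn1cnc2c(NCc3cccc(Cl)c3)ncnc21` gives 8.9%

Compound 2 stands lowest of the two numbers; the nearest, compound 1, sits higher by a gap that falls beyond the usual scatter of this assay. Compound 3 `O[C@@H]1[C@H](O)CS[C@H]1Cn1cnc2c(NCc3cccc(Cl)c3)nc(Cl)nc21` has not yet been measured in this assay. It differs from compound 2 by one change: chloro in place of hydrogen on an aromatic carbon. Among the compounds with values here, no pair of measured compounds isolates this single change, so no measured size for it exists. A modest rise in inhibition is expected rather than a loss, with the step from compound 2 to compound 3 estimated at a number 9.1 percentage points higher from compound 2 to compound 3 (within the scatter), a size that may or may not clear the scatter. For compound 3 the estimate in this assay is 18%, with a range from 5% to 32%.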

Compound 3, a percentage reported as inhibition, at one concentration (the size of the read-out at that concentration, not a potency): 13.6%
Beside the measured number, compound 3's estimate is 4.4 percentage points above it, within the range that was stated.
By their numbers in this assay, from the lowest: compounds 2, 3 and 1 (each within the scatter of the next, the first and the last beyond it).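

In this assay the aromatic carbon between two ring nitrogen atoms now has a measured step: chloro in place of hydrogen gives a number 4.7 percentage points higher from compound 2 to compound 3 (within the scatter) and so cannot be told apart from no effect at this position. On the benzyl side, chloro in place of bromo on an aromatic carbon gives a number 7.4 percentage points lower from compound 1 to compound 3 (within the scatter) and is likewise not resolved. Neither single change therefore separates its pair of compounds in this read-out, and nothing at hand accounts for either step.

On these data alone, whether an amine, a methoxy group or a longer chain on the carbon between two ring nitrogen atoms would produce a step beyond the scatter remains open. Also open, as far as these compounds go, is whether a nitrile or trifluoromethyl group in place of the benzyl halogen would do so.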